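This account rests on a few compounds, and the source may have more. Where it says the series, first, only, none or still open, it means among the compounds named here.

Measured so far in an in vitro ADME assay on microsomes from liver (Homo sapiens) for metabolic stability; a higher number here means faster removal of the compound, a lower number slower removal:
Compound 1 `COCc1nc2nc(C)cc(Nc3ccc(C(F)(F)F)cc3)n2n1` gives 6.7 mL.min-1.g-1.
Compound 2 `Cc1cc(Nc2ccc(C(F)(F)F)cc2)n2nc(C3CC3)nc2n1` gives only a limit of the assay, < 5 mL.min-1.g-1.
Compound 3 `CCc1nc2nc(C)cc(Nc3ccc(C(F)(F)F)cc3)n2n1` gives only a limit of the assay, < 5 mL.min-1.g-1.

Compound 3 stands at the floor of the numbers shown: its value is a limit, and the limit of < 5 mL.min-1.g-1 in this assay, at which 2 of the 3 values shown sit, marks where two of the three values sit. The step of an at least 1.3-fold lower number from compound 1 to compound 3 (0.12 log units; that floor lies within the scatter) carries a floor that lies within the usual scatter, as does an at least 1.3-fold lower number from compound 1 to compound 2 (0.12 log units; that floor lies within the scatter). The step that the two limits leave unreadable from compound 2 to compound 3 cannot be read, both ends being limits.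

Compound 4 `CCc1nc2nc(C)cc(Nc3ccc(Cl)cc3)n2n1` differs from compound 3 by chloro in place of trifluoromethyl on an aromatic carbon. Among the measured compounds shown here, none of the measured steps touches this group; each of them alters the substituent on the shared core instead, so no measured step bears directly on the change. The expectation therefore rests on compound 3 alone, whose value is a limit. In this assay the expected step is a step that the limit leaves unreadable from compound 3 to compound 4, no movement beyond the scatter in either direction. Compound 4 is estimated at 4 mL.min-1.g-1, with a range from 2 mL.min-1.g-1 to 10 mL.min-1.g-1, most likely reported again as a limit.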

Compound 4, intrinsic clearance in microsomes: 12.8 mL.min-1.g-1
Beside the measured number, compound 4's estimate is 3.2-fold (0.51 log units) below it; measured number outside the range, above it.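

Among the compounds shown here, the position on the six-membered aromatic ring of carbon only is the first place where a single change moves the read-out in this assay beyond the scatter: chloro in place of trifluoromethyl brings an at least 2.5-fold higher number from compound 3 to compound 4 (0.40 log units; beyond the scatter). The earlier steps shown here all altered the other substituent on the shared core, and none of them could be read beyond the scatter. The value of compound 3 is a limit, so this step gives only a floor and its full size stays unknown: the limit of < 5 mL.min-1.g-1 in this assay, at which 2 of the 4 values shown sit.

The compounds shown leave open whether chloro in place of trifluoromethyl brings a similar step with cyclopropyl or methoxymethyl on the shared core, as only the ethyl pair carries this change. Also open, as far as these compounds go, is how fluoro or a nitrile at this place would read in this assay.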